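This account rests on a few compounds, and the source may have more. Where it says the series, first, only, none or still open, it means among the compounds named here.

The three measured compounds, in order of their numbers:

compound 1, `CCN(C)C(=O)N1CCN(C(=S)SCc2cn(Cc3ccccc3F)nn2)CC1`: 15600 nM
compound 2, `CC(C)(C)NC(=O)N1CCN(C(=S)SCc2cn(Cc3ccccc3F)nn2)CC1`: 87800 nM
compound 3, `O=C(NCc1ccccc1)N1CCN(C(=S)SCc2cn(Cc3ccccc3F)nn2)CC1`: 38100 nM

In a functional assay on EC9706 cells (Homo sapiens) for cytotoxicity, read by MTT assay, with a stated time of 72 h (a lower number here means a stronger inhibitor, a higher number a weaker inhibitor), compound 1 stands lowest of the three. Compound 3 is nearest to it, with a 2.4-fold higher number from compound 1 to compound 3 (0.39 log units; beyond the scatter), and compound 2 is furthest, with a 5.6-fold higher number from compound 1 to compound 2 (0.75 log units; beyond the scatter). Between the other two, a 2.3-fold lower number from compound 2 to compound 3 (0.36 log units; beyond the scatter). All three measured steps alter only the group attached to the carbonyl carbon of the shared core.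

Compound 4, `CCN(C)C(=O)N1CCN(C(=S)SCc2cn(Cc3ccc(F)cc3)nn2)CC1`, is not yet measured. It differs from compound 1 at the other end of the core: 4-fluorophenyl in place of 2-fluorophenyl on a saturated chain carbon bound to an aromatic nitrogen. The same atoms are present in both compounds, joined differently.

Going by the values given here, none of the measured steps bears on this change. Each of them swaps the group on the carbonyl carbon and leaves the 2-fluorobenzyl untouched, so there is no comparison from which a direction or a size for moving the fluorine could be drawn. With nothing pointing either way, the expectation is a step within the usual scatter, in no particular direction.

The number expected for compound 4 in this assay is 15600 nM, with a range from 5000 nM to 50000 nM. That estimate amounts to no change at the digits printed from compound 1 to compound 4 (within the scatter).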

Compound 4, half-maximal inhibitory concentration: 14300 nM
For compound 4 the middle estimate is 1.1-fold (0.04 log units) above the measured one, and the stated range covers the measured number.
By their numbers in this assay, from the lowest: compounds 4 and 1 (each within the scatter of the next); then compound 3; then compound 2.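

In this assay, going by these compounds alone, this is the first look at the far end of the core from the carbonyl carbon: 4-fluorophenyl in place of 2-fluorophenyl on a saturated chain carbon bound to an aromatic nitrogen gives a 1.1-fold lower number from compound 1 to compound 4 (0.04 log units; within the scatter), so compounds 1 and 4 cannot be told apart. The earlier steps shown here all changed the group on the carbonyl carbon and all lay beyond the scatter, the largest being a 5.6-fold higher number from compound 1 to compound 2 (0.75 log units; beyond the scatter), whereas this swap of 2-fluorobenzyl to 4-fluorobenzyl, with exactly the same atoms rearranged, leaves no readable difference in this one pair. No supporting measurement is available to explain this result.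

The compounds shown leave open whether anything at this place matters, since a plain benzyl with no fluorine, a 4-chlorobenzyl or a 4-methoxybenzyl could still separate from compound 1. They also leave open whether 4-fluorobenzyl and 2-fluorobenzyl would remain just as hard to tell apart with benzylamino or (tert-butyl)amino on the carbonyl carbon instead of ethyl(methyl)amino.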